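From chloro to trifluoromethyl: compound 3 to compound 4

The source may report more compounds than this note shows. Statements on the series, on what has been measured and on what is new or still open speak of the compounds shown alone.

In an ADME assay on microsomes from liver (Homo sapiens) for metabolic stability, read by LC-MS, using NADPH, with stated times of 6 min and 10 min, tested at 0.5 uM (a lower number here means that less of the compound is left, a higher number that more of the compound is left), compound 1 (`CC(=O)N1CCN(c2cc(C)cc(-c3cc(Cl)c4c(N)ncnn34)c2)C(=O)C1(C)C`) gives 92%, compound 2 (`CC(=O)N1CCN(c2cc(-c3cc(Cl)c4c(N)ncnn34)ccc2C#N)C(=O)C1(C)C`) gives 90% and compound 3 (`CC(=O)N1C[C@H](C)N(c2cc(-c3cc(Cl)c4c(N)ncnn34)ccc2C#N)C(=O)C1(C)C`) gives 99%, three numbers within the usual scatter of one another. Compound 4 (`CC(=O)N1C[C@H](C)N(c2cc(-c3cc(C(F)(F)F)c4c(N)ncnn34)ccc2C#N)C(=O)C1(C)C`) carries trifluoromethyl in place of chloro on an aromatic carbon of compound 3: trifluoromethyl in place of chloro on an aromatic carbon. For the measured compounds named here, the one measured step, a number 9 percentage points higher from compound 2 to compound 3 (within the scatter), is a different change, methyl in place of hydrogen on a saturated ring carbon, so no measurement covers this swap directly. Starting from compound 3 at 99%, no step beyond the scatter is expected in this assay. The expected step is a number 6 percentage points lower from compound 3 to compound 4 (within the scatter). Compound 4 is estimated at 93%, with an expected range from 82% to 100%.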

Compound 4, percent of the compound remaining: 89%
Compound 4: the middle estimate sits 4 percentage points above what was measured; low and high end bracket the measured number.
By their numbers in this assay, from the lowest: compounds 4, 2, 1 and 3 (each within the scatter of the next).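

In this assay, putting trifluoromethyl in place of chloro gives a number 10 percentage points lower from compound 3 to compound 4 (within the scatter) and so shows that this aromatic carbon, two ring bonds from the ring nitrogen, can carry a group of four heavy atoms instead of one without a step beyond the scatter. The earlier compounds shown here all carry chloro here, so they could not show this. Nothing on hand explains the result.

From the compounds shown here alone, it remains open how an amine or a longer carbon chain on this carbon would read out. Going by these compounds, whether the same swap behaves alike on compound 1 or compound 2 also remains open.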